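A few compounds are considered here, and "the series" means these few. Any claim that something is new, unique, unknown or untested is made for them only; others in the source may bear on it.

The shared core is shown by compound 1 `C=C(CC)C(=O)c1ccc(OCC(=O)Nc2nc3ccccc3s2)c(Cl)c1Cl`, which carries a 1,3-benzothiazol-2-yl group on an amide-type nitrogen. In a functional assay on CLL cells (Homo sapiens) for cytotoxicity, read by MTT assay, with a stated time of 48 h (a higher number here means that more compound is needed for the effect, a lower number that less compound is needed), compound 1 gives 1500 nM. Compound 2 `C=C(CC)C(=O)c1ccc(OCC(=O)Nc2ccc(O)c([N+](=O)[O-])c2)c(Cl)c1Cl` holds a different group on that nitrogen, and in this assay compound 2 gives 7400 nM. Compound 3 `C=C(CC)C(=O)c1ccc(OCC(=O)NCC(=O)O)c(Cl)c1Cl` bears a carboxymethyl group on the amide-type nitrogen. In this assay compound 3 reaches only a limit of the assay, > 25000 nM, so no number is known for it. Among the compounds with values here, the only measured step touching it, an at least 16-fold higher number from compound 1 to compound 3 (1.22 log units; beyond the scatter), ended at the limit (the limit of > 25000 nM in this assay, at which 1 of the 3 values shown sits), which is where compound 3 stands.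

Compound 4 `C=C(CC)C(=O)c1ccc(OCC(=O)NCO[N+](=O)[O-])c(Cl)c1Cl` differs from compound 3 by nitrooxy in place of carboxy on a saturated chain carbon bound to an amide-type nitrogen. Within the data shown here, no measured step covers this exchange, and with compound 3 sitting at a limit the size of any step from it cannot be read from the numbers. Compound 4 is therefore estimated at 12000 nM, with a range from 3000 nM to 40000 nM. The step of an at least 2.0-fold lower number from compound 3 to compound 4 (0.31 log units; beyond the scatter) is expected to be a gain of uncertain size.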

Compound 4, half-maximal effective concentration: 4100 nM
Compound 4: the middle estimate sits 2.9-fold (0.47 log units) above what was measured; measured number inside the range.
By their numbers in this assay, from the lowest: compound 1; then compounds 4 and 2 (each within the scatter of the next). At a limit, above all of these: compound 3.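

In this assay, nitrooxy in place of carboxy on a saturated chain carbon bound to an amide-type nitrogen gives an at least 6.0-fold lower number from compound 3 to compound 4 (0.78 log units; beyond the scatter), so a group without a ring on this nitrogen can still return a measured number. The true size of that step cannot be read, because one end of it is not a number: the limit of > 25000 nM in this assay, at which 1 of the 4 values shown sits.

Even so, (nitrooxy)methyl in place of 1,3-benzothiazol-2-yl on an amide-type nitrogen gives a 2.7-fold higher number from compound 1 to compound 4 (0.44 log units; beyond the scatter), so the new group does not match the ring-bearing group on this measure.

The compounds shown do not tell whether the gain comes from having nitrooxy there or simply from losing carboxy. A hydroxy group or a methyl ester on the same chain carbon, or a longer chain carrying nitrooxy, would help separate these two readings.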